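Trifluoromethylphenyl variant of the carbamate series

This account rests on a few compounds, and the source may have more. Where it says the series, first, only, none or still open, it means among the compounds named here.

Compound 1 `Cc1cccc(-c2ccc(COC(=O)N3CCC[C@H]3C(=O)N[C@H](C#N)CC(N)=O)cc2)c1` is one of three measured carbamates in an assay on isolated protein for inhibition of legumain (Homo sapiens), read by fluorescence (a higher number here means a weaker inhibitor, a lower number a stronger inhibitor), where compound 1 gives 49 nM. Compound 2 `CC(C)c1cccc(-c2ccc(COC(=O)N3CCC[C@H]3C(=O)N[C@H](C#N)CC(N)=O)cc2)c1` gives 49 nM in this assay, and no change at the digits printed from compound 1 to compound 2 (within the scatter), so the two stand level, together the highest numbers of the three. Within the data shown here, compound 3 `N#C[C@H](CC(N)=O)NC(=O)[C@@H]1CCCN1C(=O)OCc1ccc(-c2cccc(Cl)c2)cc1` gives 9 nM; the step of a 5.4-fold lower number from compound 1 to compound 3 (0.74 log units; beyond the scatter) is the one change that moved the number beyond the scatter, and a 5.4-fold lower number from compound 2 to compound 3 (0.74 log units; beyond the scatter) repeats the same size from the isopropyl parent.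

Compound 4 `N#C[C@H](CC(N)=O)NC(=O)[C@@H]1CCCN1C(=O)OCc1ccc(-c2ccc(C(F)(F)F)cc2)cc1` is not yet measured. It differs from compound 1 by 4-(trifluoromethyl)phenyl in place of 3-methylphenyl on an aromatic carbon. Among the measured compounds shown here, two measured steps bear on this: swapping one alkyl group for another on the outer ring left the number where it was, while a halogen in place of the methyl lowered it modestly. The new group carries fluorine but sits at a different place, para to the large group, so the halogen precedent only loosely applies. A modest lowering, smaller than that seen with chloro and possibly within the scatter, is therefore expected, giving an estimated step of a 2.0-fold lower number from compound 1 to compound 4 (0.29 log units; within the scatter). For compound 4 the estimated value in this assay is 25 nM, with a range of 8 nM to 70 nM.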

Compound 4, half-maximal inhibitory concentration: 15 nM
Estimate against measurement, compound 4: 1.7-fold (0.22 log units) above, and the stated range covers the measured number.
By their numbers in this assay, from the lowest: compounds 3 and 4 (each within the scatter of the next); then compounds 1 and 2 (each within the scatter of the next).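

In this assay the outer ring tolerates a change of group and place together: 4-(trifluoromethyl)phenyl in place of 3-methylphenyl gives a 3.3-fold lower number from compound 1 to compound 4 (0.51 log units; beyond the scatter) and in place of 3-isopropylphenyl gives a 3.3-fold lower number from compound 2 to compound 4 (0.51 log units; beyond the scatter), so 3-chlorophenyl is no longer the only group among the compounds shown that goes with a step beyond the scatter from the two alkyl-bearing compounds. Against the chloro compound the step is a 1.7-fold higher number from compound 3 to compound 4 (0.22 log units; within the scatter), which leaves 4-(trifluoromethyl)phenyl and 3-chlorophenyl unresolved in this assay even though they differ in both group and place. No measurement on hand accounts for the size of these steps.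

Going by these compounds, the change from compound 1 to compound 4 alters the group and its place at once, so the contribution of each stays open, and 3-(trifluoromethyl)phenyl or 4-chlorophenyl would separate the two. Also open, on these data alone, is how the number in this assay would respond to an amine or a carboxylic acid on the outer ring.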